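Fluoro in place of cyano on a quinoline-type core

The source may hold more compounds than are shown below. What is called first, only, known or untested is meant among the compounds shown, and "the series" means these compounds.

Measured compounds:
compound 1 `O=S(=O)(c1ccc(F)cc1)c1cnc2cc(Cl)c(F)cc2c1-c1ccc(Cl)cc1` — 0.57 mL/min
compound 2 `N#Cc1ccc2ncc(S(=O)(=O)c3ccc(F)cc3)c(-c3ccc(Cl)cc3)c2c1` — 0.04 mL/min

In an ADME assay on microsomes from liver (Rattus norvegicus) for metabolic stability, tested at 2.5 uM (on this read-out lower numbers stand for slow clearance and higher numbers for fast clearance), compound 2 gives 0.04 mL/min, the lowest of the two numbers seen so far. In this assay compound 1 gives 0.57 mL/min, a gap that lies beyond the usual scatter.

Compound 3 `O=S(=O)(c1ccc(F)cc1)c1cnc2ccc(F)cc2c1-c1ccc(Cl)cc1` has not yet been measured. It differs from compound 2 in one place: fluoro in place of cyano on an aromatic carbon. Going by the values given here, no step between two measured compounds covers exactly this change, so the expectation rests on the two values shown.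

The estimated step from compound 2 to compound 3 is a 5.0-fold higher number from compound 2 to compound 3 (0.70 log units; beyond the scatter), an increase, because compound 1, which also lacks the cyano group on its core, gives 0.57 mL/min. Compound 3 is therefore expected at about 0.2 mL/min, with a range from 0.07 mL/min to 0.6 mL/min.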

Compound 3, intrinsic clearance in a liver preparation (reported as CLH), per the amount of preparation that the assay uses: 0.4 mL/min
For compound 3 the middle estimate is 2.0-fold (0.30 log units) below the measured one, within the range that was stated.
By their numbers in this assay, from the lowest: compound 2; then compounds 3 and 1 (each within the scatter of the next).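

In this assay, the change at this aromatic carbon is now seen on its own: fluoro in place of cyano gives a 10-fold higher number from compound 2 to compound 3 (1.00 log units; beyond the scatter). Hydrogen in place of chloro gives a 1.4-fold lower number from compound 1 to compound 3 (0.15 log units; within the scatter), which lies within the scatter, so among the steps shown, only the one that removes the cyano group lies beyond it. The compounds offer no measurement that accounts for the size of this step.

Going by these compounds, it remains open whether the low number of compound 2 is particular to the cyano group, or whether another group on this carbon, such as an amine, a carboxylic acid or a methoxy group, would give a similar number. Also open, on these data alone, is whether the step from cyano to fluoro would keep its size with other substituents on the shared core.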